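Swapping the Urea Terminal Ring at Constant Activity

This account rests on a few compounds, and the source may have more. Where it says the series, first, only, none or still open, it means among the compounds named here.

Compound 1 `COc1cc(Cl)cc(-c2nn(-c3cccc(NC(=O)Nc4cccc(C(F)(F)F)c4)c3)cc2-c2ccncc2)c1` is a urea-linked molecule tested in a functional assay on M14 cells (Homo sapiens) for inhibition, read by sulforhodamine B assay, with a stated time of 48 h, tested at 0.1 uM (on this read-out higher numbers stand for a weaker effect at the one concentration tested and lower numbers for a stronger effect), where compound 1 gives 93%. A close neighbour, compound 2 `O=C(Nc1cccc(-n2cc(-c3ccncc3)c(-c3cc(O)cc(Cl)c3)n2)c1)Nc1ccc(Cl)c(Cl)c1`, differs from compound 1 in two places and in this assay compound 2 gives 93%. Going by the values given here, the two numbers stand at the same digits, so compound 1 and compound 2 show no difference beyond the usual scatter, and compound 1 is simply level with its only measured neighbour.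

Compound 3 `COc1cc(Cl)cc(-c2nn(-c3cccc(NC(=O)Nc4ccc(Cl)c(Cl)c4)c3)cc2-c2ccncc2)c1` is not yet measured. It differs from compound 1 by a single change: 3,4-dichlorophenyl in place of 3-(trifluoromethyl)phenyl on an amide-type nitrogen. Among the compounds with values here, no measured pair in this set isolates exactly this exchange, so the expected size of the step rests on what the two measured compounds show. Compound 2 already carries the 3,4-dichlorophenyl group and gives 93%, the same reading as compound 1. The step from compound 1 to compound 3 is therefore expected to be small, a number 1 percentage points lower from compound 1 to compound 3 (within the scatter), with no direction beyond the scatter. Compound 3 is estimated to give 92% in this assay, within a range from 80% to 102%.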

Compound 3, a percentage reported as activity, at one concentration (the size of the read-out at that concentration, not a potency): 100%
Compound 3: the middle estimate sits 8 percentage points below what was measured; measured number inside the range.
By their numbers in this assay, from the lowest: compounds 1, 2 and 3 (each within the scatter of the next).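

In this assay, 3,4-dichlorophenyl in place of 3-(trifluoromethyl)phenyl on the amide-type nitrogen gives a number 7 percentage points higher from compound 1 to compound 3 (within the scatter), so this pair, which isolates that one exchange, does not separate the two groups at the single concentration tested. The other single change, methyl in place of hydrogen on an oxygen on an aromatic ring, gives a number 7 percentage points higher from compound 2 to compound 3 (within the scatter), so that oxygen, with or without the methyl, also shows no step beyond the scatter when the urea carries 3,4-dichlorophenyl. Nothing available explains either result.

The compounds shown leave open whether a less similar group on that nitrogen, such as a phenyl ring carrying a dimethylamino group or a carboxylic acid, or a plain butyl chain in place of the ring, would move the reading beyond the scatter. Going by these compounds, a reading at one concentration is also not a potency, so it remains open whether these compounds would still read alike across a range of concentrations.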